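The source may report more compounds than this note shows. Statements on the series, on what has been measured and on what is new or still open speak of the compounds shown alone.

Of the compounds shown here, three have been tested in a functional assay on the whole organism with Mus musculus as the target; on this read-out higher numbers stand for an effect only at larger amounts of compound and lower numbers for an effect already at smaller amounts. Compound 1 `C/C(C(=O)NC1CC1)=C(/C)c1ccc(Cl)cc1` gives 11.4 mg/kg. Compound 2 `C=CCNC(=O)/C(C)=C(\C)c1ccccc1` gives 67 mg/kg. Compound 3 `C/C(C(=O)NC1CC1)=C(\C)c1ccc(Cl)cc1` gives 36.3 mg/kg, the second highest of the three numbers; its gap to compound 2 lies within the scatter, while its gap to compound 1 lies beyond it. Going by the values given here, only one pair of measured compounds differs in a single place, and that step is a 3.2-fold higher number from compound 1 to compound 3 (0.50 log units; beyond the scatter). It rests on (the fact that compounds 1 and 3 differ only in the configuration as drawn), so it speaks about the drawn geometry of the double bond and about nothing else.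

The next compound, compound 4 `C/C(C(=O)NC1CC1)=C(\C)c1ccc(Br)cc1`, differs from compound 3 by bromo in place of chloro on an aromatic carbon. Among the compounds with values here, none of the measured steps touches a change of this kind: the only step available swaps the drawn configuration and leaves every substituent unchanged, so it offers no guide to exchanging one halogen for another on the aromatic ring. With nothing to point either way, the expectation in this assay is a step no larger than the scatter, namely a 1.0-fold lower number from compound 3 to compound 4 (0.00 log units; within the scatter). Compound 4 is therefore expected to give about 36 mg/kg in this assay, with a likely range from 15 mg/kg to 90 mg/kg.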

Compound 4, dose for half-maximal effect: 52.4 mg/kg
Compound 4: middle estimate off by 1.5-fold (0.16 log units), on the low side; the range from low to high includes it.
By their numbers in this assay, from the lowest: compound 1; then compounds 3, 4 and 2 (each within the scatter of the next).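

Exchanging chloro for bromo on an aromatic carbon para to a large group, with the rest of the structure held fixed, gives a 1.4-fold higher number from compound 3 to compound 4 (0.16 log units; within the scatter) in this assay. Going by these compounds alone, this is the first measured change to the ring substituent, since the earlier step touched only the drawn geometry of the double bond, and it shows that at this position one halogen can take the place of the other without a shift that stands out from the scatter. Nothing available bears on why the two halogens read alike, so no reason can be given for this result.

Still open, on these data alone, is whether this position stays as undemanding with a group that is not chloro or bromo, such as fluoro, methoxy, an amine or a carboxylic acid, or whether such a group would move the number clearly in either direction. Also open, as far as these compounds go, is whether bromo in place of chloro gives an equally small step on the E double bond of compound 1, the form that shows the lowest number so far.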